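Cytotoxicity of oxime ether analogues in a muscle cell line

This account rests on a few compounds, and the source may have more. Where it says the series, first, only, none or still open, it means among the compounds named here.

Compound 1 `CCO/N=C/c1ccc(OCCC(C)CCN2CCN(c3ccccc3)C2=O)cc1`: > 100000 nM
Compound 2 `CCO/N=C/c1cc(C)c(OCCC(C)CCN2CCN(c3ccnc(N)c3)C2=O)c(C)c1`: 12900 nM
Compound 3 `CC(CCOc1ccc(/C=N/O)cc1)CCN1CCN(c2ccnc(N)c2)C1=O`: > 100000 nM

Of the compounds shown here, three have been tested in an ADME assay on RD cells (Homo sapiens) for cytotoxicity, read by MTT assay, with a stated time of 24 h; on this read-out higher numbers stand for lower toxicity in this test and lower numbers for higher toxicity in this test. Compound 1 reaches only the limit of the test, giving > 100000 nM in this assay. Compound 2 gives a number, 12900 nM in this assay. Compound 3 likewise sits at the limit, with > 100000 nM in this assay, so no number is available for it; it shares that position with compound 1 (the limit of > 100000 nM in this assay, at which 2 of the 3 values shown sit), and only compound 2 falls inside the range of this assay.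

The step under consideration leads from compound 3 to compound 4 `CCONCc1ccc(OCCC(C)CCN2CCN(c3ccnc(N)c3)C2=O)cc1`, which is not yet measured. The change is a group of 5 heavy atoms (3 carbon, 1 nitrogen, 1 oxygen; no ring) in place of a group of 3 heavy atoms (1 carbon, 1 nitrogen, 1 oxygen; no ring), on an aromatic carbon.

Within the data shown here, since no step between measured compounds is available, the expectation for compound 4 rests on the limit of compound 3 and on compound 1. Compound 4 is expected to stay near the limit, with an estimated step of a number no higher from compound 3 to compound 4 (the limit leaves the size open) that lies within the usual scatter. For compound 4 the estimate in this assay is 100000 nM, within 30000 nM to 300000 nM.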

Compound 4, half-maximal cytotoxic concentration: 7370 nM
Compound 4: middle estimate off by 14-fold (1.13 log units), on the high side; the measured number lies below the stated range.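

In this assay, placing (ethoxyamino)methyl on this aromatic carbon, para to a large group, gives an at least 13-fold lower number from compound 3 to compound 4 (1.13 log units; beyond the scatter), so a change at this one place is enough to bring a compound inside the range of the test. The size of that step is itself a bound, and the real gap may be wider, since compound 3 has a limit and not a number: the limit of > 100000 nM in this assay, at which 2 of the 4 values shown sit. The leaving group carries a double bond outside aromatic rings and the entering group does not, but the two also differ in heavy atoms, so this single step cannot separate those features.

The compounds shown leave open whether the ethyl on oxygen or the saturated link carries the change. On these data alone, a simple aminomethyl group, a methoxyaminomethyl group or a longer chain on the oxygen at this place would address that, and how far the number falls with each remains unknown.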